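The compounds below may be only part of what the source reports. "The series", "measured", "known", "first", "only" and "open" are said of these compounds alone.

Compound 1, `CN(C(=O)NC(=O)c1ccc(Cl)cc1Cl)c1nc(C(F)(F)F)c(C(=O)N/N=C/c2cccc(C(F)(F)F)c2)s1`, and compound 3, `CN(C(=O)NC(=O)c1ccc(Cl)cc1Cl)c1nc(C(F)(F)F)c(C(=O)N/N=C/c2ccccc2C(F)(F)F)s1`, share one core and differ in a single group: in compound 3 there is 2-(trifluoromethyl)phenyl in place of 3-(trifluoromethyl)phenyl on a carbon with a double bond to nitrogen. In a functional assay on MCF7 cells (Homo sapiens) for inhibition, read by MTT assay, with a stated time of 72 h (on this read-out lower numbers stand for stronger inhibition and higher numbers for weaker inhibition), compound 1 gives 10.7 ug/mL, and compound 3 gives 9.12 ug/mL, so the step is a 1.2-fold lower number from compound 1 to compound 3 (0.07 log units; within the scatter). Both numbers therefore describe much the same strength of inhibition, and the change of group left the read-out essentially where it was.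

Compound 2, `Cc1nc(N(C)C(=O)NC(=O)c2c(F)cccc2F)sc1C(=O)N/N=C/c1cccc(C(F)(F)F)c1`, is built on a different core; how its core differs from the core of compound 1 is not broken down here. In this assay compound 2 gives 28.2 ug/mL, the highest of the three numbers, with the gaps to compound 1 and compound 3 both beyond the usual scatter of repeated measurements.

Compound 4, `Cc1nc(N(C)C(=O)NC(=O)c2c(F)cccc2F)sc1C(=O)N/N=C/c1ccccc1C(F)(F)F`, has not yet been measured. It stands to compound 2 exactly as compound 3 stands to compound 1: 2-(trifluoromethyl)phenyl in place of 3-(trifluoromethyl)phenyl on a carbon with a double bond to nitrogen, with the surroundings of the place the same in both pairs, so it is the same change made on the other core. Since that change gave only a 1.2-fold lower number from compound 1 to compound 3 (0.07 log units; within the scatter), a step of similar size is expected here, a 1.1-fold lower number from compound 2 to compound 4 (0.05 log units; within the scatter), with compound 4 staying close to compound 2. Compound 4 is therefore estimated to give 25 ug/mL in this assay, most likely between 12 ug/mL and 50 ug/mL.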

Compound 4, half-maximal inhibitory concentration: 7.34 ug/mL
Compound 4: the middle estimate sits 3.4-fold (0.53 log units) above what was measured; the whole stated range lies above it.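

Moved onto the core of compound 2, the swap of 3-(trifluoromethyl)phenyl for 2-(trifluoromethyl)phenyl gives a 3.8-fold lower number from compound 2 to compound 4 (0.58 log units; beyond the scatter) in this assay, so a change that did almost nothing on one core makes a clear difference on the other. The size of this step therefore did not carry over from one core to the other, and a result from one core would have been a poor guide to the other: the same change on two cores in this assay, a 1.2-fold lower number (0.07 log units; within the scatter) from compound 1 to compound 3 and a 3.8-fold lower number (0.58 log units; beyond the scatter) from compound 2 to compound 4, 3.3-fold (0.52 log units) apart, beyond the scatter of two such steps

Among these compounds, this shows that the core matters for this particular change, but it rests on only two pairs of compounds, so it gives no general rule for the series, and it does not show which part of the two cores is responsible or why the step differs.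

On these data alone, whether a plain phenyl, or a phenyl carrying a methoxy group or a nitrile in place of trifluoromethyl, would respond to the core in the same way stays open. Also open, as far as these compounds go, is how the same swap would behave on a third core, or in a cell line other than the one used here, since all four numbers come from a single test.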